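Capping the free hydroxy of compound 1

The source may hold more compounds than are shown below. What is called first, only, known or untested is meant among the compounds shown, and "the series" means these compounds.

Among the compounds with values here, in a functional assay on HT-29 cells (Homo sapiens) for cytotoxicity, read by MTT assay, with a stated time of 6 days (on this read-out higher numbers stand for an effect only at larger amounts of compound and lower numbers for an effect already at smaller amounts), compound 1 `COc1cc(-c2cc(=O)c3cc(O)ccc3o2)cc(OC)c1OC` gives 7.85 ug/mL, the only actual number so far. Compound 2 `COc1cc(-c2cc(=O)c3cc(O)ccc3o2)cc(OC)c1O` gives > 25 ug/mL in this assay, which is a limit of the assay and not a number. Compound 3 `COc1ccc2oc(-c3cc(OC)c(OC)c(OC)c3)cc(=O)c2c1` is the next case, and its change from compound 1 is methyl in place of hydrogen on an oxygen on an aromatic ring, or hydroxy to methoxy.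

Within the data shown here, one measured step bears on this. Hydrogen in place of methyl on an oxygen on an aromatic ring gives an at least 3.1-fold higher number from compound 1 to compound 2 (0.50 log units; beyond the scatter), a step beyond the scatter. That step runs the opposite way and concerns a different oxygen, so it offers only weak guidance on direction and little on size. A free hydroxy was not favoured there, which points to a lower number on capping, but a smaller shift is likely. The expected step in this assay is a 1.3-fold lower number from compound 1 to compound 3 (0.12 log units; within the scatter), and it may not clear the scatter. Compound 3 is estimated at 6 ug/mL, with an expected range of 2 ug/mL to 20 ug/mL.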

Compound 3, concentration for half-maximal effect: > 25 ug/mL
Compound 3 was reported as a limit; the forecaster's own chance of this, stated with the estimate: 10%; middle value at least 4.1-fold (0.61 log units) away from the limit.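

In this assay compound 3 gives > 25 ug/mL, which is a limit of the assay and not a number. Hydroxy to methoxy on this oxygen gives an at least 3.1-fold higher number from compound 1 to compound 3 (0.50 log units; beyond the scatter), so the free hydroxy at this position cannot be capped with methyl without losing the measurable effect seen for compound 1. Read beside an at least 3.1-fold higher number from compound 1 to compound 2 (0.50 log units; beyond the scatter), the opposite change at a different oxygen, this shows that the two oxygens do not behave alike and that each single change away from compound 1 leads to the same limit, so the true size of both steps stays unread because the values stop there: the limit of > 25 ug/mL in this assay, at which 2 of the 3 values shown sit.

The compounds shown leave open whether any other group on this oxygen, such as ethyl or a longer chain, gives a number again, and whether an amine or a carboxylic acid in place of the hydroxy does. They also leave open how far compound 3 lies from compound 1 beyond the bound printed with the step.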